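Swapping phenoxy for 3-chlorophenyl on compound 2

This account rests on a few compounds, and the source may have more. Where it says the series, first, only, none or still open, it means among the compounds named here.

In an ADME assay on liver for metabolic stability, with Liver microsome (Homo sapiens) as the target, using microsomes (on this read-out higher numbers stand for fast clearance and lower numbers for slow clearance), compound 2 (`O=C(Nc1cc(-c2ccccn2)n[nH]1)N1CCC(Oc2ccccc2)CC1`) gives 27.3 mL.min-1.g-1. Compound 1 (`N#Cc1ccc(OC2CCN(C(=O)Nc3cc(-c4ccccn4)n[nH]3)CC2)cc1`) gives 14.7 mL.min-1.g-1, and the two agree within the usual scatter. Compound 3 (`O=C(NCc1cccc(Cl)c1)Nc1cc(-c2ccccn2)n[nH]1`) stands well apart at 184 mL.min-1.g-1, the highest of the three numbers.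

Compound 4 (`O=C(Nc1cc(-c2ccccn2)n[nH]1)N1CCC(c2cccc(Cl)c2)CC1`) is not yet measured. It differs from compound 2 in one place: 3-chlorophenyl in place of phenoxy on a saturated ring carbon. Among the measured compounds shown here, the only measured step, a 1.9-fold higher number from compound 1 to compound 2 (0.27 log units; within the scatter), is a different change, hydrogen in place of cyano on an aromatic carbon, so it says little here. For the measured compounds named here, no measured step covers the new swap directly. Compound 3 also carries a 3-chlorophenyl group, but it differs from compound 2 in more than one place, so the number for compound 3 at 184 mL.min-1.g-1 is only a weak hint towards a higher number. On that hint, a modest rise is expected rather than a jump to that level. The expected step is a 2.0-fold higher number from compound 2 to compound 4 (0.30 log units; within the scatter). For compound 4 the estimate is 55 mL.min-1.g-1, with an expected range of 22 mL.min-1.g-1 to 130 mL.min-1.g-1.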

Compound 4, intrinsic clearance in microsomes: 30.8 mL.min-1.g-1
Estimate against measurement, compound 4: 1.8-fold (0.25 log units) above; measured number inside the range.
By their numbers in this assay, from the lowest: compounds 1, 2 and 4 (each within the scatter of the next, the first and the last beyond it); then compound 3.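

In this assay, placing 3-chlorophenyl in place of phenoxy on this saturated ring carbon gives a 1.1-fold higher number from compound 2 to compound 4 (0.05 log units; within the scatter), so exchanging these two groups, which have the same heavy-atom count, produces no readable difference at this position. Measured against 4-cyanophenoxy on the same carbon, 3-chlorophenyl gives a 2.1-fold higher number from compound 1 to compound 4 (0.32 log units; beyond the scatter), a modest step and the only one at this position that lies beyond the scatter. Nothing available gives a reason for either step.

On these data alone, all the groups compared on this carbon contain an aromatic ring of carbon only, so the effect of an amine, a carboxylic acid or a longer chain there remains open. Also open, as far as these compounds go, is how plain phenyl or 4-chlorophenyl on the same carbon would read in this assay.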